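The source may hold more compounds than are shown below. What is called first, only, known or untested is meant among the compounds shown, and "the series" means these compounds.

Measured in an assay on liver for inhibition of squalene monooxygenase (Rattus norvegicus), using microsomes; on this read-out lower numbers stand for stronger inhibition and higher numbers for weaker inhibition:

Compound 1 `CC(C)=CCC/C(C)=C/CC/C(C)=C/CC/C=C(\C)CCC1OC1(C)CCC=C(C)C`: 31800 nM
Compound 2 `CC(C)=CCC/C(C)=C/CC/C(C)=C/CCC1OC1(C)CC/C=C(\C)CCC=C(C)C`: 50900 nM

Among the compounds with values here, both numbers sit high on this assay, and the gap between compound 2 and compound 1 lies within the usual scatter, so the two are treated as equal; no step between measured compounds is available here. Compound 3 `CC(C)=CCC/C(C)=C/CC/C(C)=C/CCC1OC1(C)CC/C=C(\C)CC[C@@H]1OC1(C)C` has not yet been measured. It differs from compound 2 in one place: 3,3-dimethyloxiran-2-yl in place of 2-methylprop-1-en-1-yl on a saturated chain carbon, two bonds along the chain from a double-bonded chain carbon. In plain words, 3,3-dimethyloxiran-2-yl takes the place of 2-methylprop-1-en-1-yl on a saturated chain carbon, two bonds along the chain from a double-bonded chain carbon, so compound 3 carries two oxirane rings where compound 2 carries one. Nothing in the two measured compounds tells how a second oxirane at this end of the chain alters the number, and compound 1, which carries its single oxirane at the chain end, gives a number within the scatter of compound 2. The step from compound 2 to compound 3 is therefore expected to be small, a 1.5-fold lower number from compound 2 to compound 3 (0.16 log units; within the scatter), and not beyond the scatter in either direction. On that basis compound 3 is estimated at 35000 nM, with a range from 10000 nM to 120000 nM.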

Compound 3, half-maximal inhibitory concentration: 13000 nM
Estimate against measurement, compound 3: 2.7-fold (0.43 log units) above; low and high end bracket the measured number.
By their numbers in this assay, from the lowest: compound 3; then compounds 1 and 2 (each within the scatter of the next).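

In this assay, the replacement of 2-methylprop-1-en-1-yl by 3,3-dimethyloxiran-2-yl on a saturated chain carbon, two bonds along the chain from a double-bonded chain carbon, gives a 3.9-fold lower number from compound 2 to compound 3 (0.59 log units; beyond the scatter). Within the data shown here, this shows that the number responds to the group at this place, and that a second oxirane ring, added to the one compound 2 already carries, goes with stronger inhibition here, although the step is modest. The compounds shown offer no evidence for why the number moves.

On these data alone, it stays open whether the oxirane ring itself matters or whether any oxygen-bearing group at this place would do the same, as a vicinal diol, a ketone or an amine there could show. Also open, as far as these compounds go, are the other configuration at the defined stereocentre of the 3,3-dimethyloxiran-2-yl group and whether the same step would appear if compound 2 lost its first oxirane ring, leaving the 3,3-dimethyloxiran-2-yl group as the only one in the chain.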